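The source may hold more compounds than are shown below. What is called first, only, known or untested is meant among the compounds shown, and "the series" means these compounds.

Compound 3, `Cc1c(C(=O)N/N=C\c2c(O)cccc2F)oc2cccc(O)c12`, gives 8050 nM in a functional assay on PC-3 cells (Homo sapiens) for inhibition (a lower number here means a stronger inhibitor, a higher number a weaker inhibitor), the highest of the two numbers seen. Compound 1, `Cc1c(C(=O)N/N=C\c2cc(F)ccc2O)oc2cccc(O)c12`, gives 3170 nM; the step of a 2.5-fold higher number from compound 1 to compound 3 (0.40 log units; beyond the scatter) runs against compound 3. Compound 2, `Cc1c(C(=O)N/N=C\c2cccc(F)c2)oc2cccc(O)c12`, returns only a limit in this assay, >= 40000 nM (the limit of >= 40000 nM in this assay, at which 1 of the 3 values shown sits). The step of an at least 4.9-fold lower number from compound 2 to compound 3 (0.69 log units; beyond the scatter) favours compound 3.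

Compound 4, `COc1cccc(/C=N\NC(=O)c2oc3cccc(O)c3c2C)c1`, has not been measured. It differs from compound 3 by 3-methoxyphenyl in place of 2-fluoro-6-hydroxyphenyl on a carbon with a double bond to nitrogen. The most telling earlier step is an at least 12-fold higher number from compound 1 to compound 2 (1.10 log units; beyond the scatter), where the hydroxy left the ring and the number rose sharply; compound 4 likewise carries no hydroxy on that ring. A large weakening step a 3.7-fold higher number from compound 3 to compound 4 (0.57 log units; beyond the scatter) is therefore expected, with a fair chance of only a limit. Compound 4 is estimated at 30000 nM, within 10000 nM to 80000 nM.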

Compound 4, half-maximal inhibitory concentration: >= 40000 nM
Compound 4: only a limit was reported (the forecaster's own chance of this, stated with the estimate: 50%); middle value at least 1.3-fold (0.12 log units) away from the limit.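

In this assay, swapping either hydroxy-bearing ring for 3-methoxyphenyl costs clear ground: an at least 4.9-fold higher number from compound 3 to compound 4 (0.69 log units; beyond the scatter) and an at least 12-fold higher number from compound 1 to compound 4 (1.10 log units; beyond the scatter). Compound 2 was the only ring without hydroxy until now, so compound 4 shows that a second such ring, carrying methoxy instead of fluoro, also fails to keep a measurable number. The step between compound 2 and compound 4 cannot be read, because both sit at the same limit: the limit of >= 40000 nM in this assay, at which 2 of the 4 values shown sit.

From the compounds shown here alone, whether an amine or a carboxylic acid on this ring could stand in for the hydroxy remains open.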